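A ring swap on the sulfonamide of compound 2

This account rests on a few compounds, and the source may have more. Where it says the series, first, only, none or still open, it means among the compounds named here.

Compound 1 `O=S(=O)(Nc1ncccn1)c1ccc(Nc2nncc3ccccc23)cc1` measures 29 nM here
Compound 2 `O=S(=O)(Nc1nccs1)c1ccc(Nc2nncc3ccccc23)cc1` measures 34 nM here

Both numbers come from a functional assay on HT-29 cells (Homo sapiens) for antiproliferative activity, read by sulforhodamine B assay, with a stated time of 72 h (a lower number here means a stronger inhibitor, a higher number a weaker inhibitor), and are all that has been measured so far. Compound 2 stands level with compound 1, since the two values lie within the usual scatter of each other.

Compound 3 `O=S(=O)(Nc1ccccn1)c1ccc(Nc2nncc3ccccc23)cc1` has not yet been measured. It carries pyridin-2-yl in place of 1,3-thiazol-2-yl on a sulfonamide nitrogen and keeps the rest of compound 2 unchanged.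

Among the compounds with values here, only one measured step bears on this change. It exchanges one ring for another on the same sulfonamide nitrogen, 1,3-thiazol-2-yl in place of pyrimidin-2-yl, and it gives a 1.2-fold higher number from compound 1 to compound 2 (0.07 log units; within the scatter) as its whole effect. Within the data shown here, a single step is thin evidence, and no measured compound yet shows what pyridin-2-yl does at this place. Even so, that small step gives no reason to expect a shift beyond the scatter in this assay from this swap.

The expected change is a 1.1-fold lower number from compound 2 to compound 3 (0.03 log units; within the scatter) and no more. The estimate for compound 3 is 32 nM (expected range 13 nM to 80 nM).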

Compound 3, half-maximal inhibitory concentration: 38 nM
Beside the measured number, compound 3's estimate is 1.2-fold (0.07 log units) below it; the measured number falls inside the stated range.
By their numbers in this assay, from the lowest: compounds 1, 2 and 3 (each within the scatter of the next).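

The pyridin-2-yl ring brings a six-membered aromatic ring with 1 hetero atom to the sulfonamide nitrogen where 1,3-thiazol-2-yl had a five-membered aromatic ring with 2, yet in this assay the step reads a 1.1-fold higher number from compound 2 to compound 3 (0.05 log units; within the scatter). Set against the pyrimidin-2-yl ring, the step reads a 1.3-fold higher number from compound 1 to compound 3 (0.12 log units; within the scatter), so compounds 1, 2 and 3 all stand level, and this place now tolerates three different aromatic rings, of two ring sizes, without a shift beyond the scatter. Nothing measured here says why these three rings read alike.

All three groups are aromatic rings carrying hetero atoms and no further substituent, so the compounds shown leave open whether the level reading would hold for a plain phenyl ring or for a non-aromatic group such as a short alkyl chain or a piperidine ring. They also leave open whether an amine or a carboxylic acid placed on one of these rings would keep the number level or move it beyond the scatter.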